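This account rests on a few compounds, and the source may have more. Where it says the series, first, only, none or still open, it means among the compounds named here.

Measured so far:
- compound 1 `Cn1c(NN)nc(-c2ccc(Cl)cc2)c(C#N)c1=O`: 41 ug/mL
- compound 2 `COc1cccc(-c2nc(SC)n(C)c(=O)c2C#N)c1OC`: 43 ug/mL

Among the compounds with values here, in a functional assay, with a stated time of 10 min (on this read-out lower numbers stand for stronger inhibition and higher numbers for weaker inhibition), compound 1 gives 41 ug/mL, the lowest of the two numbers so far. Compound 2 gives 43 ug/mL, a value that sits within the scatter of the number for compound 1, so the two cannot be told apart on this read-out. Compound 3 `COc1ccc(-c2nc(NN)n(C)c(=O)c2C#N)cc1` has not yet been measured. It differs from compound 1 in a single place: methoxy in place of chloro on an aromatic carbon. Within the data shown here, no pair of measured compounds shows what this exchange does to the read-out, so the expectation rests on the fact that both measured compounds, one of them carrying methoxy groups, give numbers close to each other. For compound 3 the step expected from that is a 1.2-fold higher number from compound 1 to compound 3 (0.09 log units; within the scatter), small, leaning toward weaker inhibition if anything, and within the scatter. Compound 3 is expected to give about 50 ug/mL, with a range from 20 ug/mL to 120 ug/mL.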

Compound 3, half-maximal inhibitory concentration: 32 ug/mL
Beside the measured number, compound 3's estimate is 1.6-fold (0.19 log units) above it; low and high end bracket the measured number.
By their numbers in this assay, from the lowest: compounds 3, 1 and 2 (each within the scatter of the next).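

In this assay, within the data shown here, the exchange of chloro for methoxy on an aromatic carbon, para to a large group, gives a 1.3-fold lower number from compound 1 to compound 3 (0.11 log units; within the scatter) and is the first direct reading at this position. On this read-out, methoxy can therefore stand in for chloro here without a change that can be told from the scatter, so this exchange gives no sign that the read-out depends on which of the two groups is present. Nothing measured here offers an explanation for this outcome.

From the compounds shown here alone, it remains open whether plain hydrogen, fluoro or an amine at the same place would shift the number beyond the scatter. A longer chain such as ethoxy or butoxy in place of methoxy also remains untested by the compounds shown.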